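This account rests on a few compounds, and the source may have more. Where it says the series, first, only, none or still open, it means among the compounds named here.

Compound 3 `Cn1c(=O)c2c(nc(C3CCC3)n2C)n(C)c1=O` gives the highest number of the three measured in an assay for binding affinity to adenosine receptor A1 (Rattus norvegicus), read by radioligand binding (on this read-out lower numbers stand for stronger inhibition and higher numbers for weaker inhibition), with compound 3 at 30000 nM. The nearest neighbour is compound 1 `Cn1c(-c2ccccc2)nc2c1c(=O)[nH]c(=O)n2C`, which in this assay gives 3400 nM, a gap beyond the scatter; the furthest is compound 2 `CCCn1c(=O)c2nc(C)[nH]c2n(CCC)c1=O`, which in this assay gives 600 nM, a gap also beyond the scatter. None of these pairs differ in one place only, so no single change can be read off among them.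

Compound 4 `CCC/C=C/c1nc2c(c(=O)n(C)c(=O)n2C)n1C` is the next member, not yet measured in this assay. The change from compound 3 is pent-1-en-1-yl in place of cyclobutyl on an aromatic carbon. Among the compounds with values here, no measured pair shows this change, and no measured pair shares the fully methylated core of compound 3 while varying only the group on that aromatic carbon, so the size of the step has no direct precedent here. A modest move towards a lower number is expected, of a size at the edge of the scatter, giving a 2.5-fold lower number from compound 3 to compound 4 (0.40 log units; beyond the scatter). The estimate for compound 4 in this assay is 12000 nM, with a range from 3000 nM to 40000 nM.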

Compound 4, inhibition constant: 9100 nM
Compound 4: the middle estimate sits 1.3-fold (0.12 log units) above what was measured; measured number inside the range.
By their numbers in this assay, from the lowest: compound 2; then compound 1; then compound 4; then compound 3.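

Within the data shown here, on the aromatic carbon between two ring nitrogen atoms, with the shared core held fixed, pent-1-en-1-yl in place of cyclobutyl gives a 3.3-fold lower number from compound 3 to compound 4 (0.52 log units; beyond the scatter) in this assay, the first single-place step. The number at this position therefore responds to the group it carries, although this one change removes a four-membered ring, adds a double bond outside the aromatic rings and lengthens the group by one carbon, all at once. No measurement at hand bears on what lies behind the step.

Open, going by these compounds, is whether a saturated pentyl chain, a shorter chain or an amine on the same carbon would move the number, and in which direction. The lower numbers of compound 1 and compound 2 remain unassigned: each differs from compound 4 in more than one place.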